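Cytotoxicity notes on a thiazole oxalamide series

This account rests on a few compounds, and the source may have more. Where it says the series, first, only, none or still open, it means among the compounds named here.

Measured compounds:
compound 1 `Cc1nc(C(NC(=O)C(=O)Nc2ccc(F)c(F)c2)C2CCCCN2)sc1CO`, > 87000 nM
compound 2 `CC(=O)c1ccc(NC(=O)C(=O)NC(c2nc(C)c(CO)s2)C2CCCCN2)cc1`, > 107000 nM
compound 3 `CC(=O)c1ccc(NC(=O)C(=O)NC(c2nc(C)c(CCO)s2)C2CCCCN2)cc1`, > 48300 nM

In an ADME assay on MT2 cells (Homo sapiens) for cytotoxicity, read by XTT assay, with a stated time of 4 days (a lower number here means that less compound is tolerated, a higher number that more compound is tolerated), compound 2 reaches only a limit, > 107000 nM. Compound 1 in this assay likewise gives a limit, > 87000 nM. Compound 3 in this assay also gives a limit, > 48300 nM. The change from compound 2 to compound 1 is 3,4-difluorophenyl in place of 4-acetylphenyl on an amide-type nitrogen; the step that the two limits leave unreadable from compound 2 to compound 1 cannot be read because of the limit of > 107000 nM in this assay, at which 1 of the 3 values shown sits, and (the limit of > 87000 nM in this assay, at which 1 of the 3 values shown sits). The cores of compound 2 and compound 3 differ by hydroxymethyl in place of hydroxy on a saturated chain carbon bound to an aromatic carbon; the step that the two limits leave unreadable from compound 2 to compound 3 is unreadable due to the limit of > 107000 nM in this assay, at which 1 of the 3 values shown sits, and (the limit of > 48300 nM in this assay, at which 1 of the 3 values shown sits).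

Compound 4 `Cc1nc(C(NC(=O)C(=O)Nc2ccc(F)c(F)c2)C2CCCCN2)sc1CCO` is not yet measured. It differs from compound 3 by 3,4-difluorophenyl in place of 4-acetylphenyl on an amide-type nitrogen, the same change as from compound 2 to compound 1, at the same place. Since all three measured values sit at limits, compound 4 is expected to show no measurable cytotoxicity either, with the step that the limit leaves unreadable from compound 3 to compound 4 estimated as essentially flat. Compound 4 is estimated at 100000 nM in this assay, between 45000 nM and 220000 nM.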

Compound 4, half-maximal cytotoxic concentration: > 78200 nM
Compound 4: a limit, no number (the forecaster's own chance of this, stated with the estimate: 85%); the middle value is on the limit's open side.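

In this assay compound 4 gives > 78200 nM as a limit, and with compound 1 and compound 3 also at limits, the steps linking compound 4 to each of them cannot be read. The compounds shown leave open the concentration at which any of them becomes cytotoxic in this assay and whether either change alters it.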